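This account rests on a few compounds, and the source may have more. Where it says the series, first, only, none or still open, it means among the compounds named here.

Within the data shown here, in a functional assay on NCI-H1581 cells (Homo sapiens) for antiproliferative activity, read by CCK-8 assay, with a stated time of 72 h (a lower number here means a stronger inhibitor, a higher number a weaker inhibitor), compound 1 (`COc1cc(OC)c(Cl)c(-c2ccc3c(NC(=O)c4ccc(N5CCN(C)CC5)cc4)n[nH]c3n2)c1Cl`) gives 1.7 nM, the lowest of the two numbers measured so far. Compound 2 (`COc1cc(OC)c(Cl)c(-c2ccc3c(NC(=O)c4ccc(C5CCN(C)CC5)cc4)n[nH]c3n2)c1Cl`) gives 8.2 nM. Among the measured compounds shown here, the single measured step is a 4.8-fold higher number from compound 1 to compound 2 (0.68 log units; beyond the scatter), a modest change beyond the scatter, with 1-methylpiperidin-4-yl in place of 4-methylpiperazin-1-yl on an aromatic carbon.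

Compound 3 (`COc1cc(C(=O)Nc2n[nH]c3nc(-c4c(Cl)c(OC)cc(OC)c4Cl)ccc23)ccc1N1CCN(C)CC1`) keeps the 4-methylpiperazin-1-yl group of compound 1 and has methoxy in place of hydrogen on an aromatic carbon, ortho to that group: methoxy in place of hydrogen on an aromatic carbon.

For the measured compounds named here, no measured step adds a methoxy, so the evidence is indirect. Going by the values given here, compound 2 shows only that a change to the 4-methylpiperazin-1-yl group itself moved the number, by a 4.8-fold higher number from compound 1 to compound 2 (0.68 log units; beyond the scatter). A step of similar or smaller size is therefore the working expectation in this assay, tilted towards a higher number, with no firm basis for the direction. The expected step is a 1.8-fold higher number from compound 1 to compound 3 (0.25 log units; within the scatter). The estimate for compound 3 is 3 nM, with an expected range of 0.8 nM to 12 nM.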

Compound 3, half-maximal inhibitory concentration: 15.6 nM
The estimate for compound 3 lay 5.2-fold (0.72 log units) below the measured number; the whole stated range lies below it.
By their numbers in this assay, from the lowest: compound 1; then compounds 2 and 3 (each within the scatter of the next).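

In this assay, the number proves sensitive to a change outside the 4-methylpiperazin-1-yl group itself: methoxy in place of hydrogen on an aromatic carbon, ortho to that group and meta to a large group, gives a 9.2-fold higher number from compound 1 to compound 3 (0.96 log units; beyond the scatter). The earlier step, a 4.8-fold higher number from compound 1 to compound 2 (0.68 log units; beyond the scatter), altered the group itself, whereas here the group stays intact and an entering methoxy of 2 heavy atoms on its six-membered aromatic ring is enough to raise the number beyond the scatter, so this carbon does not tolerate every substitution without a change in the read-out. Nothing measured on these compounds accounts for the rise.

Still open, as far as these compounds go, is whether the rise is specific to methoxy or would also follow a fluorine, a chlorine, a methyl or a hydroxyl group on the same carbon, and whether methoxy on another carbon of this ring would give a similar step. Also open, from the compounds shown here alone, is whether methoxy on this ring would move the number in the same direction alongside the 1-methylpiperidin-4-yl group of compound 2, or alongside a morpholine in place of the 4-methylpiperazin-1-yl group.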